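The source may report more compounds than this note shows. Statements on the series, on what has been measured and on what is new or still open speak of the compounds shown alone.

Measured in an ADME assay on MDBK cells (Bos taurus) for cytotoxicity, read by MTT assay, with a stated time of 96 h; on this read-out higher numbers stand for lower toxicity in this test and lower numbers for higher toxicity in this test:
compound 1 `COc1ccc(-c2nc3cc(C(F)(F)F)ccc3[nH]2)c(N)c1` gives 4000 nM
compound 2 `Fc1cccc(F)c1-c1nc2cc(Cl)c(Cl)cc2[nH]1` gives 43000 nM
compound 3 `CN1CCN(CC(=O)Nc2ccc(-c3nc4cc(Cl)c(Cl)cc4[nH]3)cc2)CC1` gives 90000 nM

In this assay compound 1 stands lowest of the three numbers; compound 2 sits above it and compound 3 further still, both gaps beyond the scatter. For the measured compounds named here, no step between measured compounds differing in one place is available, so nothing is known about how one change moves the read-out.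

Compound 4 `COc1ccc(-c2nc3cc(C(F)(F)F)ccc3[nH]2)c([N+](=O)[O-])c1` differs from compound 1 by nitro in place of amino on an aromatic carbon, placed ortho to a large group and meta to the methoxy group. Going by the values given here, with no comparable step in hand, the step from compound 1 to compound 4 is expected to be small, likely within the scatter, with a slight lean toward a lower number. Compound 4 is therefore estimated at 3500 nM, range 1200 nM to 12000 nM, meaning an expected step of a 1.1-fold lower number from compound 1 to compound 4 (0.06 log units; within the scatter).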

Compound 4, half-maximal cytotoxic concentration: 55000 nM
Beside the measured number, compound 4's estimate is 16-fold (1.20 log units) below it; the measured number lies above the stated range.
By their numbers in this assay, from the lowest: compound 1; then compounds 2, 4 and 3 (each within the scatter of the next, the first and the last beyond it).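

In this assay, for the compounds shown here, the first one-place change, nitro in place of amino on an aromatic carbon ortho to a large group and meta to a methoxy group, gives a 14-fold higher number from compound 1 to compound 4 (1.14 log units; beyond the scatter) and shows that the read-out responds strongly to what stands at this position. The low number of compound 1 therefore depends on this position and does not belong to the shared core alone. Nothing measured here explains the step.

Going by these compounds, whether the amino group lowers the number or the nitro group raises it stays open. A hydrogen or an acetamide at this carbon would help separate the two.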